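A few compounds are considered here, and "the series" means these few. Any claim that something is new, unique, unknown or untested is made for them only; others in the source may bear on it.

Compound 2, `C=CCNc1[nH]nc2nnn(-c3ccc(OCC)cc3)c(=O)c12`, is one of three compounds examined for cytotoxicity on a human liver cell line in a functional assay on Huh-7 cells (Homo sapiens) for cytotoxicity, read by resazurin assay, with a stated time of 48 h; a higher number here means a weaker inhibitor, a lower number a stronger inhibitor. In this assay compound 2 gives 4940 nM. Compound 1, `CCOc1ccc(NC(=O)c2c(N)n[nH]c2Nc2ccccc2)cc1`, gives 4320 nM in this assay, and compound 3, `CCOc1ccc(NC(=O)/C(C#N)=C(\NC)SC)cc1`, gives 5780 nM. The three numbers lie within the usual scatter of one another, so compound 2 cannot be told apart from compound 1 or from compound 3 on these data; all three sit in the same low-micromolar band of cytotoxicity.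

Compound 4, `CCOc1ccc(-n2nnc3n[nH]c(Nc4ccccc4)c3c2=O)cc1`, shares the core of compound 2 and differs from it in one place: phenyl in place of allyl on a nitrogen on an aromatic ring. Among the measured compounds shown here, no step between two measured compounds isolates this change, so there is nothing in the data to say which way it would move the number. Given that the three measured compounds, with quite different structures, all fall in one narrow band, compound 4 is expected to stay in that band as well, with a step from compound 2 that is expected to be a 1.0-fold lower number from compound 2 to compound 4 (0.01 log units; within the scatter), none beyond the scatter. Compound 4 is therefore estimated at 4800 nM in this assay, with a likely range from 2000 nM to 11000 nM.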

Compound 4, half-maximal inhibitory concentration: 9390 nM
Beside the measured number, compound 4's estimate is 2.0-fold (0.29 log units) below it, within the range that was stated.
By their numbers in this assay, from the lowest: compounds 1, 2, 3 and 4 (each within the scatter of the next, the first and the last beyond it).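

In this assay, among the compounds shown here, the exchange of allyl for phenyl on a nitrogen on an aromatic ring gives a 1.9-fold higher number from compound 2 to compound 4 (0.28 log units; within the scatter) and is the only step in this set that isolates a single change, since the earlier compounds differed from one another in more than one place. The step stays within the scatter even though the exchange removes a double bond outside aromatic rings, brings in a six-membered aromatic ring of carbon only and raises the group from 3 heavy atoms to 6, so these data cannot separate allyl from phenyl at this position. No measurement shown bears on what lies behind this step.

The compounds shown leave open whether any group at this nitrogen would move the number beyond the scatter, for example a longer chain such as hexyl, a benzyl group, or a phenyl ring carrying a carboxylic acid or an amine. They also leave open whether the same exchange of allyl for phenyl would give a step of similar size on a different core.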